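A 3-Bromophenyl Group Replaces 4-Hydroxyphenyl on an Oxygen

A few compounds are considered here, and "the series" means these few. Any claim that something is new, unique, unknown or untested is made for them only; others in the source may bear on it.

In a functional assay on MCF7 cells (Homo sapiens) for antiproliferative activity, read by MTT assay, with a stated time of 72 h (a higher number here means a weaker inhibitor, a lower number a stronger inhibitor), compound 1 `Cc1ccccc1OS(=O)(=O)C1CC2OC1C(c1ccc(/C=C/c3cc(O)cc(O)c3)cc1)=C2c1ccc(O)cc1` gives 55800 nM, compound 2 `Cc1cccc(OS(=O)(=O)C2CC3OC2C(c2ccc(/C=C/c4cc(O)cc(O)c4)cc2)=C3c2ccc(O)cc2)c1` gives 16300 nM, and compound 3 `O=S(=O)(Oc1ccc(O)cc1)C1CC2OC1C(c1ccc(/C=C/c3cc(O)cc(O)c3)cc1)=C2c1ccc(O)cc1` gives 14100 nM. Thus a 1.2-fold lower number from compound 2 to compound 3 (0.06 log units; within the scatter) lies within the scatter, while a 4.0-fold lower number from compound 1 to compound 3 (0.60 log units; beyond the scatter) lies beyond it, leaving compound 3 level with compound 2. Compound 4 `O=S(=O)(Oc1cccc(Br)c1)C1CC2OC1C(c1ccc(/C=C/c3cc(O)cc(O)c3)cc1)=C2c1ccc(O)cc1` carries 3-bromophenyl in place of 4-hydroxyphenyl on an oxygen. Among the measured compounds shown here, no bromine-bearing compound has been measured, so the closest guide is the 3-methylphenyl group of compound 2, where a 1.2-fold lower number from compound 2 to compound 3 (0.06 log units; within the scatter) shows no step beyond the scatter. An estimated 1.1-fold higher number from compound 3 to compound 4 (0.03 log units; within the scatter) is therefore expected, with no change beyond the scatter. Compound 4 is expected at 15000 nM, with an estimated range of 6000 nM to 38000 nM.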

Compound 4, half-maximal inhibitory concentration: 19800 nM
Beside the measured number, compound 4's estimate is 1.3-fold (0.12 log units) below it; the range from low to high includes it.
By their numbers in this assay, from the lowest: compounds 3, 2 and 4 (each within the scatter of the next); then compound 1.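

In this assay the exchange of 4-hydroxyphenyl for 3-bromophenyl on the oxygen bound to the sulfonyl sulfur removes the hydrogen-bond donor and acceptor counted for the leaving group, yet gives a 1.4-fold higher number from compound 3 to compound 4 (0.15 log units; within the scatter) and so leaves the number level. Bromo in place of methyl gives a 1.2-fold higher number from compound 2 to compound 4 (0.08 log units; within the scatter) while a 2.8-fold lower number from compound 1 to compound 4 (0.45 log units; beyond the scatter) shows that compound 4 stays apart from the 2-methylphenyl compound. Nothing available here explains these numbers. Still open, going by these compounds, is whether a phenyl group carrying an amine or a carboxylic acid would move the number beyond the scatter, and whether bromine placed elsewhere on the phenyl group would do so.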